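The compounds below may be only part of what the source reports. "The series", "measured", "known", "first", "only" and "open" are said of these compounds alone.

Measured so far in a functional assay on Hep 3B2 cells (Homo sapiens) for inhibition, read by sulforhodamine B assay, with a stated time of 72 h; on this read-out lower numbers stand for stronger inhibition and higher numbers for weaker inhibition:
- compound 1 `CCS(=O)(=O)c1ccc(OC)c(Nc2nc(-c3cccc(-c4ccccn4)c3)co2)c1`: 900 nM
- compound 2 `Cc1ccc([S@+]([O-])C2=C(Cl)C(=O)C=CC2=O)cc1`: "not active" (no number reported)
- compound 3 `Cc1ccc([S@+]([O-])C2=CC(=O)C=CC2=O)cc1`: 17400 nM

Of the two numbers available in this assay, the higher belongs to compound 3 at 17400 nM, which makes it the weaker of the pair. Compound 1 reads 900 nM, lower by more than the scatter. Compound 2 gave no number and was reported as "not active" (no number reported).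

Compound 4 `COC1=CC(=O)C([S@@+]([O-])c2ccc(C)cc2)=CC1=O` has not yet been measured. It differs from compound 3 by a single change: methoxy in place of hydrogen on a double-bonded ring carbon. Within the data shown here, no step between measured compounds is available to size this change, so the expectation in this assay is for no shift beyond the scatter. A weaker result remains possible, since compound 2 gave only "not active" (no number reported). The expected step runs a 1.2-fold lower number from compound 3 to compound 4 (0.06 log units; within the scatter). The estimate for compound 4 is 15000 nM, with an expected range from 5000 nM to 50000 nM.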

Compound 4, half-maximal inhibitory concentration: 9900 nM
Beside the measured number, compound 4's estimate is 1.5-fold (0.18 log units) above it, within the range that was stated.
By their numbers in this assay, from the lowest: compound 1; then compounds 4 and 3 (each within the scatter of the next).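

In this assay, methoxy in place of hydrogen on a double-bonded ring carbon gives a 1.8-fold lower number from compound 3 to compound 4 (0.24 log units; within the scatter) and so produces no shift that can be told apart from repeat measurement. Among these compounds, this is the only change on the shared core that can be sized so far, and it shows that this carbon, three ring bonds from the ring atom that bears the group of 9 heavy atoms, can carry a methoxy group while the number stays within the scatter. Nothing at hand offers an explanation for this result.

From the compounds shown here alone, whether an amine or a longer chain such as butoxy on this carbon would also stay within the scatter of compound 3 remains open. Also open, going by these compounds, is whether a carboxylic acid here would move the number beyond the scatter in either direction.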